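Two limits and a methyl-for-chloro swap

The source may report more compounds than this note shows. Statements on the series, on what has been measured and on what is new or still open speak of the compounds shown alone.

Among the compounds with values here, compound 2 `Clc1ccc(Cc2nn3c(Br)c(-c4ccc(Cl)cc4)nc3s2)cc1` and compound 1 `Fc1ccc(-c2cn3nc(Cc4ccc(Cl)cc4)sc3n2)cc1` are the two measured members of the set. In an ADME assay on CCRF-CEM cells (Homo sapiens) for cytotoxicity, with a stated time of 72 h (a higher number here means a weaker inhibitor, a lower number a stronger inhibitor), compound 1 gives only a limit, > 250000 nM. In this assay compound 2 likewise gives only a limit, > 250000 nM. Compound 2 thus stands at the limit of > 250000 nM in this assay, at which 2 of the 2 values shown sit; nothing further is known of its strength beyond that limit. Compound 3 `Cc1ccc(-c2nc3sc(Cc4ccc(Cl)cc4)nn3c2Br)cc1` is not yet measured. It differs from compound 2 by methyl in place of chloro on an aromatic carbon. Within the data shown here, no measured step ties this change to a number in this assay. Given that both recorded values rest at the limit, the expected step in this assay is none beyond the scatter, a number no higher from compound 2 to compound 3 (the limit leaves the size open). Compound 3 is therefore expected to return a limit again, estimated at 250000 nM, within 80000 nM to 1000000 nM.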

Compound 3, half-maximal inhibitory concentration: > 250000 nM
Compound 3 gave a limit, no number; the forecaster's own chance of this, stated with the estimate: 80%; the middle value lies on the limit itself.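

Compound 2 and compound 3 both give only a limit in this assay, so no step can be read for the change from 4-chlorophenyl to 4-methylphenyl. The compounds shown leave open whether that change has any effect and what strength any of them would show as an actual number in this assay.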